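Aryl Ester Replaces Pyrazolylethyl Ether on a Shared Core

The source may hold more compounds than are shown below. What is called first, only, known or untested is meant among the compounds shown, and "the series" means these compounds.

Compound 1 `Cc1cc(C)n(CCOC2CC(=O)Nc3c2c(C)nn3-c2ncnc3nc[nH]c23)n1` carries a 2-(3,5-dimethyl-1H-pyrazol-1-yl)ethyl group on an oxygen on a saturated carbon. In a functional assay on HEK293 cells for agonist activity at G-protein coupled receptor 39 (Homo sapiens), read by scintillation proximity assay and inositol phosphate accumulation, with a stated time of 75 min, in the presence of a further agent that is not named here (a higher number here means that more compound is needed for the effect, a lower number that less compound is needed), compound 1 gives 16 nM, the highest of the three numbers recorded. Compound 2 `Cc1nn(-c2ncnc3nc[nH]c23)c2c1C(OCc1ccccc1C#N)CC(=O)N2` gives 8 nM and compound 3 `Cc1nn(-c2ncnc3nc[nH]c23)c2c1C(OCc1ccc(C#N)cc1)CC(=O)N2` gives 4 nM. The step of a 2.0-fold lower number from compound 1 to compound 2 (0.30 log units; within the scatter), and the step of a 4.0-fold lower number from compound 1 to compound 3 (0.60 log units; beyond the scatter). Compound 4 `Cc1nn(-c2ncnc3nc[nH]c23)c2c1C(OC(=O)c1ccc(F)cc1)CC(=O)N2` differs from compound 1 in one place: (4-fluorophenyl)carbonyl in place of 2-(3,5-dimethyl-1H-pyrazol-1-yl)ethyl on an oxygen on a saturated carbon. The two measured steps show that swapping the pyrazolyl group for a cyanophenyl ring lowered the number at most modestly, but neither introduced a carbonyl in this position, so they bear only loosely on compound 4. A step of a 1.1-fold lower number from compound 1 to compound 4 (0.03 log units; within the scatter) is therefore expected, and compound 4 is estimated at 15 nM, with a range from 4 nM to 60 nM.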

Compound 4, half-maximal effective concentration: 4 nM
Estimate against measurement, compound 4: 3.8-fold (0.57 log units) above, and the stated range covers the measured number.
By their numbers in this assay, from the lowest: compounds 3, 4, 2 and 1 (each within the scatter of the next, the first and the last beyond it).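

In this assay the change to (4-fluorophenyl)carbonyl on this oxygen gives a 4.0-fold lower number from compound 1 to compound 4 (0.60 log units; beyond the scatter) and so shows that a carbonyl directly on the oxygen is compatible with a low number. Against the two cyanobenzyl compounds it gives no change at the digits printed from compound 3 to compound 4 (within the scatter) and a 2.0-fold lower number from compound 2 to compound 4 (0.30 log units; within the scatter) and so does not separate the carbonyl-linked group from them. Nothing measured here explains these numbers.

The compounds shown leave open what part the fluorine plays in compound 4. They also leave open what a benzoyl group without fluorine, or a longer chain ending in a carboxylic acid, would give on this oxygen.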